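The source may hold more compounds than are shown below. What is called first, only, known or untested is meant among the compounds shown, and "the series" means these compounds.

In an assay on membranes from CHO cells for displacement of a labelled ligand from adenosine receptor A1 (Homo sapiens), read by scintillation counting, with a stated time of 60 min, tested at 1 uM (on this read-out higher numbers stand for more inhibition at the one concentration tested (going by the name of the read-out) and lower numbers for less inhibition), the measured compounds stand as follows:

compound 1 `COC(=O)C1=C(C)NC(=O)NC1c1cccs1`: 6%
compound 2 `CC1=C(C(=O)CC(C)C)C(c2cccs2)NC(=O)N1`: 19%
compound 3 `CC1=C(c2ncc(C)o2)C(c2cccs2)NC(=O)N1`: 21%

Compound 2 holds the second highest of the three numbers in this assay. The nearest gap is a number 2 percentage points higher from compound 2 to compound 3 (within the scatter), which lies within the scatter, so those two compounds cannot be ranked against each other; the widest gap is a number 13 percentage points higher from compound 1 to compound 2 (beyond the scatter), a modest rise beyond the scatter. The unmeasured compound 4 `CCC(C)OC(=O)C1=C(C)NC(=O)NC1c1cccs1` differs from compound 2 in one place: sec-butoxy in place of isobutyl on a carbonyl carbon. Compound 4 is therefore an ester like compound 1, though with sec-butoxy where compound 1 carries methoxy. Going by the values given here, the one measured step that touches this spot is a number 13 percentage points higher from compound 1 to compound 2 (beyond the scatter), where isobutyl in place of methoxy brought a modest rise. Returning to an ester might give part of that rise back, but no measured step tells whether a sec-butoxy ester sits nearer to compound 1 or to compound 2. Compound 4 is expected to show a step of a number 7 percentage points lower from compound 2 to compound 4 (within the scatter). Compound 4 is estimated at 12%, between 2% and 24%.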

Compound 4, a percentage reported as inhibition, at one concentration (the size of the read-out at that concentration, not a potency): 5%
For compound 4 the middle estimate is 7 percentage points above the measured one; measured number inside the range.
By their numbers in this assay, from the lowest: compounds 4 and 1 (each within the scatter of the next); then compounds 2 and 3 (each within the scatter of the next).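

In this assay, sec-butyl in place of methyl on an oxygen next to a carbonyl group gives a number 1 percentage points lower from compound 1 to compound 4 (within the scatter), so enlarging the alkyl part of this ester leaves the number unchanged within the scatter. Sec-butoxy in place of isobutyl on a carbonyl carbon gives a number 14 percentage points lower from compound 2 to compound 4 (beyond the scatter), even though both groups hold the same count of carbon, so across compounds 1, 2 and 4 the number follows whether the group is attached through oxygen, not how large it is. No measurement of any other kind is available to explain this difference.

On these data alone, whether the isobutyl result extends to other groups on this carbonyl carbon remains open, for instance an amine, which would make an amide, or a longer chain attached through carbon. As far as these compounds go, a carboxylic acid at the same place is equally open.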